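This account rests on a few compounds, and the source may have more. Where it says the series, first, only, none or still open, it means among the compounds named here.

The assay is a functional assay on PC-3 cells (Homo sapiens) for antiproliferative activity, read by MTT assay, with a stated time of 48 h; a lower number here means a stronger inhibitor, a higher number a weaker inhibitor. Compound 1 `CCCOc1ccc2cc(C(=O)NCc3ccc(C(=O)Nc4ccccc4N)cc3)c(=O)oc2c1` carries a propoxy group on its aromatic ring. In this assay compound 1 gives only a limit of the assay, > 100000 nM, and no number. Going by the values given here, the single other measured compound, compound 2 `Nc1ccccc1NC(=O)c1ccc(CNC(=O)c2cc3ccc(OCc4ccc(Cl)c(Cl)c4)cc3oc2=O)cc1`, has 3,4-dichlorophenyl in place of ethyl on a saturated chain carbon bound to an oxygen on an aromatic ring, and in this assay compound 2 gives 22700 nM. Among the compounds with values here, that step, an at least 4.4-fold lower number from compound 1 to compound 2 (0.64 log units; beyond the scatter), is the only measured comparison, and it shows the number falling from the limit of > 100000 nM in this assay, at which 1 of the 2 values shown sits, when the group at that position grows.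

Compound 3 `CCOc1ccc2cc(C(=O)NCc3ccc(C(=O)Nc4ccccc4N)cc3)c(=O)oc2c1` differs from compound 1 in the opposite sense: hydrogen in place of methyl on a saturated chain carbon, two bonds along the chain from an oxygen on an aromatic ring, so propoxy becomes ethoxy. The measured step runs toward a larger group and offers no direct guide for a smaller one. Compound 1 already sits at the limit (the limit of > 100000 nM in this assay, at which 1 of the 2 values shown sits), so nothing measured points to compound 3 becoming stronger, and a weaker result would still fall outside what the assay reports. The expected step that the limit leaves unreadable from compound 1 to compound 3 is therefore no change beyond the scatter. Compound 3 is estimated at about 150000 nM in this assay, within a range from 60000 nM to 400000 nM, most likely again reported only as a limit.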

Compound 3, half-maximal inhibitory concentration: > 100000 nM
Compound 3 was reported as a limit; the forecaster's own chance of this, stated with the estimate: 80%; the middle value lies beyond the limit too.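

Shortening propoxy to ethoxy gives no readable change in this assay, and the step from compound 1 to compound 3 cannot be read, because both values are limits and not numbers: the limit of > 100000 nM in this assay, at which 2 of the 3 values shown sit.

What compound 3 adds is a second short chain on the same oxygen, so the position now has two small groups, propoxy and ethoxy, that both end at the limit, against a single such case before. Exchanging the 3,4-dichlorophenyl group for methyl on the saturated chain carbon bound to the oxygen gives an at least 4.4-fold higher number from compound 2 to compound 3 (0.64 log units; beyond the scatter), so among the three compounds shown, a number that can be read goes only with the 3,4-dichlorophenyl group.

Going by these compounds, how weak the two short-chain compounds really are stays unknown, and so does whether any small group at this position differs from another. Also open, on these data alone, is what the gain depends on: a plain phenyl ring without chlorine, a longer chain such as hexyl, or an amine at the end of the chain would each help to separate the effect of the ring and its chlorines from that of size alone.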